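Swapping the ortho halide aryl ring in a metabolic stability series

This account rests on a few compounds, and the source may have more. Where it says the series, first, only, none or still open, it means among the compounds named here.

The shared core of compound 1 `Nc1nc(NCCNc2ncc(-c3ncc[nH]3)c(-c3ccccc3Cl)n2)ccc1[N+](=O)[O-]` carries a 2-chlorophenyl group. In an ADME assay on microsomes from liver (Canis lupus familiaris) for metabolic stability (on this read-out lower numbers stand for a shorter-lived compound and higher numbers for a longer-lived compound), compound 1 gives > 0.5 h, which is a limit of the measurement rather than a number. Compound 2 `Nc1nc(NCCNc2ncc(-c3ncc[nH]3)c(-c3ccc(F)cc3F)n2)ccc1[N+](=O)[O-]` is its close relative with 2,4-difluorophenyl in place of 2-chlorophenyl. In this assay compound 2 gives > 0.5 h, again a limit. Going by the values given here, the only measured step, a step that the two limits leave unreadable from compound 1 to compound 2, therefore cannot be sized, and the one piece of evidence is the limit of > 0.5 h in this assay, at which 2 of the 2 values shown sit. Compound 3 `Cc1ccc(-c2nc(NCCNc3ccc([N+](=O)[O-])c(N)n3)ncc2-c2ncc[nH]2)c(Br)c1` differs from compound 1 as follows: 2-bromo-4-methylphenyl in place of 2-chlorophenyl on an aromatic carbon. Among the compounds with values here, no measured step shows how exchanging one halogenated phenyl ring for another moves the half-life in this assay, so no direction is expected beyond the scatter. Compound 3 is expected to give 1 h in this assay, between 0.4 h and 3 h, an estimated step that the limit leaves unreadable from compound 1 to compound 3 from compound 1, most likely reported as a limit once more.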

Compound 3, half-life: > 0.5 h
Compound 3: only a limit was reported; the forecaster's own chance of this, stated with the estimate: 70%; the middle value is on the limit's open side.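

Compound 3 also gives only a limit, so none of the steps among compound 1, compound 2 and compound 3 in this assay can be read: the limit of > 0.5 h in this assay, at which 3 of the 3 values shown sit.

The compounds shown leave open how long each half-life really is, and whether exchanging these halogenated phenyl rings changes it at all.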